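The source may hold more compounds than are shown below. What is called first, only, known or untested is meant among the compounds shown, and "the series" means these compounds.

Of the compounds shown here, two have been measured in a functional assay on HepG2 cells (Homo sapiens) for cytotoxicity, read by MTT assay, with a stated time of 48 h; on this read-out lower numbers stand for stronger inhibition and higher numbers for weaker inhibition. Compound 1 `CCCCCCCCCCCCCCNC(=O)[C@@H](NC(=O)c1ccco1)[C@@H](C)O` carries a (furan-2-yl)carbonyl group on the amine nitrogen of the shared core, and in this assay compound 1 shows > 400000 nM, which is a limit of the assay rather than a measured number. Compound 2 `CCCCCCCCCCCCCCNC(=O)[C@@H](NS(=O)(=O)c1ccc(C)cc1)[C@@H](C)O` bears a (4-methylphenyl)sulfonyl group in that place instead, and in this assay compound 2 gives 10900 nM. The step of an at least 36-fold lower number from compound 1 to compound 2 (1.56 log units; beyond the scatter) is the only measured one, and it rests on a limit, (the limit of > 400000 nM in this assay, at which 1 of the 2 values shown sits). Compound 2 thus stands as the only compound with a number shown. Compound 3 `CCCCCCCCCCCCCCNC(=O)[C@@H](NS(=O)(=O)c1ccc2ccccc2c1)[C@@H](C)O` differs from compound 2 by a single change: naphthalen-2-yl in place of 4-methylphenyl on a sulfonyl sulfur. No measured step touches the group on the sulfonyl sulfur; the one step shown swaps an acyl group for a sulfonyl group, which compound 3 keeps. Only a modest shift is expected, and compound 3 is estimated at 6000 nM in this assay, with a range from 2000 nM to 25000 nM. The step that this estimate means is expected to be a 1.8-fold lower number from compound 2 to compound 3 (0.26 log units; within the scatter).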

Compound 3, half-maximal inhibitory concentration: 11400 nM
Estimate against measurement, compound 3: 1.9-fold (0.28 log units) below; the measured number falls inside the stated range.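

In this assay, replacing 4-methylphenyl with naphthalen-2-yl on the sulfonyl sulfur adds a second six-membered aromatic ring of carbon, yet it gives a 1.0-fold higher number from compound 2 to compound 3 (0.02 log units; within the scatter) and compound 2 and compound 3 cannot be told apart on this read-out. Going by these compounds alone, the earlier step changed only the kind of group on the amine nitrogen, so this is the first measured change to the group on the sulfonyl sulfur itself, and here a clearly larger carbon-only aromatic group leaves the number within the usual scatter of repeated measurements. The compounds shown offer no measurement that explains why this exchange makes so little difference.

Going by these compounds, with only these two carbon-only aromatic groups on the sulfonyl sulfur, it remains open whether a much smaller group such as methyl, or an aromatic ring carrying an amine or a carboxylic acid, would move the number beyond the scatter. Also open, on these data alone, is how much of the cytotoxicity depends on the long carbon chain that all three compounds share, which a shorter chain in its place could test.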